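This account rests on a few compounds, and the source may have more. Where it says the series, first, only, none or still open, it means among the compounds named here.

Of the compounds shown here, three have been measured in a functional assay on HEK293 cells for agonist activity at Bile acid receptor (Homo sapiens); a higher number here means a larger maximal response, a lower number a smaller maximal response. Compound 1 `CC(C)c1onc(-c2c(Cl)cccc2Cl)c1COc1ccc(N(C)C(=O)c2ccc(C(=O)O)cc2)c(C(F)(F)F)n1` gives 36%. Compound 2 `CC(C)c1onc(-c2c(Cl)cccc2Cl)c1COc1ccc(NC(=O)c2ccc(C(=O)O)cc2)c(C(F)(F)F)n1` gives 21%. Compound 3 `Cc1cc(OCc2c(-c3c(Cl)cccc3Cl)noc2C(C)C)nc2ccccc12` gives 40%.

Compound 2 stands lowest of the three numbers in this assay. Within the data shown here, its nearest neighbour is compound 1, and the only measured step that differs in one place is the one between them: a number 15 percentage points lower from compound 1 to compound 2 (beyond the scatter), brought about by hydrogen in place of methyl on an amide-type nitrogen. Among the measured compounds shown here, compound 3 lies higher still, and its gap to compound 2 is also beyond the scatter, though no single-place step connects the two.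

Compound 4 `CC(C)c1onc(-c2c(Cl)cccc2Cl)c1COc1ccc(NCc2ccc(C(=O)O)cc2)c(C(F)(F)F)n1` has not been measured. It differs from compound 2 by 4-carboxybenzyl in place of (4-carboxyphenyl)carbonyl on a nitrogen on an aromatic ring. The 4-carboxyphenyl ring stays, but the carbonyl through which it was joined to the nitrogen in compound 2 is gone.

For the measured compounds named here, no measured step changes this part of the molecule. Going by the values given here, the one step at hand, a number 15 percentage points lower from compound 1 to compound 2 (beyond the scatter), alters what sits on the same nitrogen but leaves the (4-carboxyphenyl)carbonyl intact, so it gives no direction for the present change. With nothing to point up or down, the expected step of a number 4 percentage points higher from compound 2 to compound 4 (within the scatter) is small and within the scatter. Compound 4 is therefore estimated at 25%, expected to fall between 10% and 45%.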

Compound 4, largest response reached (reported as efficacy), in percent of the reference or control that the assay uses: 48%
Compound 4: the middle estimate sits 23 percentage points below what was measured, and the stated range ends below it.
By their numbers in this assay, from the lowest: compound 2; then compounds 1, 3 and 4 (each within the scatter of the next, the first and the last beyond it).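

In this assay, the link that joins the 4-carboxyphenyl ring to the nitrogen on the aromatic ring clearly matters: exchanging (4-carboxyphenyl)carbonyl for 4-carboxybenzyl gives a number 27 percentage points higher from compound 2 to compound 4 (beyond the scatter) and is the larger of the two measured changes at this nitrogen. The ring and its carboxylic acid stay, and the counts change only by one oxygen, one double bond outside aromatic rings and one hydrogen-bond acceptor, so a small edit to the link alone is enough to shift the maximal response beyond the scatter. The earlier step, a number 15 percentage points lower from compound 1 to compound 2 (beyond the scatter), had shown only that the response depends on what else the nitrogen carries while the carbonyl stays in place, and nothing measured here explains why removing the carbonyl raises the response.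

The compounds shown leave open whether a longer chain, such as a two-carbon link, or a sulfonyl group in the same place would raise or lower the response further. They also leave open whether a methyl on the nitrogen of the 4-carboxybenzyl compound would act as it does on the amide.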